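The source may report more compounds than this note shows. Statements on the series, on what has been measured and on what is new or still open speak of the compounds shown alone.

In an ADME assay on HEK-293T cells (Homo sapiens) for cytotoxicity, read by MTT assay, with a stated time of 24 h (on this read-out higher numbers stand for lower toxicity in this test and lower numbers for higher toxicity in this test), three compounds sharing one core have been measured so far. Compound 1 (`Cc1ccc(-c2nn(-c3ccccc3)cc2-c2nc3ccccc3n2S(=O)(=O)c2ccccc2)cc1`) reads 138000 nM there, compound 2 (`Cc1ccc(-c2nn(-c3ccccc3)cc2-c2nc3ccccc3n2S(=O)(=O)c2ccc(Cl)cc2)cc1`) reads 167000 nM there, and compound 3 (`Cc1ccc(-c2nn(-c3ccccc3)cc2-c2nc3ccccc3n2S(=O)(=O)c2ccc(Br)cc2)cc1`) reads 159000 nM there. Compound 1 thus stands level with the other two, since all three values lie within the scatter of one another.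

Compound 4 (`O=S(=O)(c1ccccc1)n1c(-c2cn(-c3ccccc3)nc2-c2ccc(C(F)(F)F)cc2)nc2ccccc21`) has yet to be measured. It differs from compound 1 by a single change (trifluoromethyl in place of methyl on an aromatic carbon), trifluoromethyl in place of methyl on an aromatic carbon, para to a large group. The same difference can be read as 4-methylphenyl to 4-(trifluoromethyl)phenyl.

The measured steps bear on this only indirectly, as none of them replaces the methyl group. Chloro in place of hydrogen gave one step (a 1.2-fold higher number from compound 1 to compound 2 (0.08 log units; within the scatter)), bromo in place of hydrogen gave another (a 1.2-fold higher number from compound 1 to compound 3 (0.06 log units; within the scatter)), and bromo in place of chloro gave a third (a 1.1-fold lower number from compound 2 to compound 3 (0.02 log units; within the scatter)). All three stayed within the scatter, so the series has so far shown no substitution that moves the value. On that basis no change beyond the scatter is expected in this assay here, and the estimated step (a 1.1-fold higher number from compound 1 to compound 4 (0.04 log units; within the scatter)) has no meaningful direction. Compound 4 is expected at 150000 nM with an estimated range of 80000 nM to 280000 nM around that figure.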

Compound 4, half-maximal cytotoxic concentration: 128000 nM
Compound 4: middle estimate off by 1.2-fold (0.07 log units), on the high side; measured number inside the range.
By their numbers in this assay, from the lowest: compounds 4, 1, 3 and 2 (each within the scatter of the next).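

Among the compounds shown, only compound 4 carries a change at the methyl group of the 4-methylphenyl, and in this assay trifluoromethyl in place of methyl on this aromatic carbon, para to a large group, gives (a 1.1-fold lower number from compound 1 to compound 4 (0.03 log units; within the scatter)). The value therefore stays level at this second site of change even with four heavy atoms entering where one leaves, as it did when chloro and bromo entered elsewhere on compound 1. No measurement shown here offers an explanation for this flat result.

The compounds shown leave open whether this position stays as level with a group of a different kind in place of the methyl, such as an amine, a carboxylic acid or a longer chain, since both groups compared here have no hydrogen-bond donors or acceptors and no net charge. They also leave open whether trifluoromethyl at this position combined with chloro or bromo at the other site would read the same way in this assay as each change does alone.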